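This account rests on a few compounds, and the source may have more. Where it says the series, first, only, none or still open, it means among the compounds named here.

Measured compounds in an ADME assay on microsomes from liver (Homo sapiens) for metabolic stability, tested at 2.5 uM; on this read-out higher numbers stand for fast clearance and lower numbers for slow clearance:
- compound 1 `O=S(=O)(c1cccc(F)c1)c1cnc2c(F)cccc2c1-c1cccc(Cl)c1`: 0.56 mL/min
- compound 2 `O=S(=O)(c1ccc(F)cc1)c1cnc2c(F)cccc2c1-c1cccc(F)c1`: 1.56 mL/min
- compound 3 `O=S(=O)(c1ccc(F)c(Cl)c1)c1cnc2c(F)cccc2c1-c1cccc(F)c1`: 1.23 mL/min

Compound 3 holds the second highest of the three numbers in this assay. Its nearest neighbour is compound 2, and the step of a 1.3-fold lower number from compound 2 to compound 3 (0.10 log units; within the scatter) lies within the scatter, so these two cannot be ordered. Compound 1 stands further off, with a number that lies beyond the scatter below that of compound 3.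

Compound 4 `O=S(=O)(c1cccc(F)c1)c1cnc2c(F)cccc2c1-c1cccc(F)c1` differs from compound 3 by 3-fluorophenyl in place of 3-chloro-4-fluorophenyl on a sulfonyl sulfur. Among the compounds with values here, no measured step reproduces this exact change. Within the data shown here, the only single-point step that touches the same sulfonyl group is a 1.3-fold lower number from compound 2 to compound 3 (0.10 log units; within the scatter), which adds a chloro and stays within the scatter; compound 4 removes that chloro again while the fluorine sits in a different ring position. Among the measured compounds shown here, compound 1, which also carries a 3-fluorophenyl on the sulfonyl sulfur, gives a lower number, but it differs from compound 4 elsewhere, so no step is counted for that pair.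

The account therefore expects a 1.1-fold lower number from compound 3 to compound 4 (0.05 log units; within the scatter) for compound 4, a change not clearly beyond the scatter. Compound 4 is estimated at 1.1 mL/min, with a range of 0.6 mL/min to 2 mL/min.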

Compound 4, intrinsic clearance in a liver preparation (reported as CLH), per the amount of preparation that the assay uses: 1.14 mL/min
For compound 4 the middle estimate is 1.0-fold (0.02 log units) below the measured one; the measured number falls inside the stated range.
By their numbers in this assay, from the lowest: compound 1; then compounds 4, 3 and 2 (each within the scatter of the next).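

In this assay, 3-fluorophenyl in place of 3-chloro-4-fluorophenyl on a sulfonyl sulfur gives a 1.1-fold lower number from compound 3 to compound 4 (0.03 log units; within the scatter) and 3-fluorophenyl in place of 4-fluorophenyl gives a 1.4-fold lower number from compound 2 to compound 4 (0.14 log units; within the scatter), so the three aryl groups carried by compounds 2, 3 and 4 cannot be ordered on this read-out. With the sulfonyl aryl group held as 3-fluorophenyl, fluoro in place of chloro on an aromatic carbon gives a 2.0-fold higher number from compound 1 to compound 4 (0.31 log units; beyond the scatter), a modest step, and the only one of the three beyond the scatter. Nothing shown here accounts for either finding.

The compounds shown leave open whether a non-aryl group on the sulfonyl sulfur, such as a morpholine or a short alkyl chain, would move the number beyond the scatter. They also leave open whether fluoro in place of chloro gives a similar step alongside the 4-fluorophenyl or 3-chloro-4-fluorophenyl groups.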